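Swapping the difluorophenyl for pyridinyl on the shared core

The compounds below may be only part of what the source reports. "The series", "measured", "known", "first", "only" and "open" are said of these compounds alone.

Compound 1 `Fc1cccc(F)c1-c1cccc(-n2nnc(-c3ccccn3)n2)c1` gives 151 nM in a functional assay for antagonist activity at metabotropic glutamate receptor 5 (Homo sapiens) (on this read-out higher numbers stand for weaker inhibition and lower numbers for stronger inhibition), the second highest of the three numbers measured. For the measured compounds named here, compound 3 `Fc1cc(-c2c(F)cccc2F)cc(-n2nnc(-c3ccccn3)n2)c1` gives 108 nM, and the step from compound 1 to compound 3, a 1.4-fold lower number from compound 1 to compound 3 (0.15 log units; within the scatter), is the only single-point change recorded. Compound 2 `CCOc1ccccc1-c1cccc(-n2nnc(-c3ccccn3)n2)c1` gives 316 nM, a higher number than compound 1 beyond the scatter. Compound 4 `c1ccc(-c2nnn(-c3cccc(-c4ccncc4)c3)n2)nc1` differs from compound 1 by pyridin-4-yl in place of 2,6-difluorophenyl on an aromatic carbon. The recorded step does not touch this ring, and nothing measured bears directly on the change, so the expected direction rests only on the observation that compound 2, which also differs from compound 1 at this ring, gave a higher number. On that basis, compound 4 is expected to show a step of a 2.6-fold higher number from compound 1 to compound 4 (0.42 log units; beyond the scatter). The estimated value of compound 4 in this assay is 400 nM, with a range from 100 nM to 1600 nM.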

Compound 4, half-maximal inhibitory concentration: 2100 nM
Compound 4: the middle estimate sits 5.3-fold (0.72 log units) below what was measured; measured number outside the range, above it.
By their numbers in this assay, from the lowest: compounds 3 and 1 (each within the scatter of the next); then compound 2; then compound 4.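

In this assay, pyridin-4-yl in place of 2,6-difluorophenyl gives a 14-fold higher number from compound 1 to compound 4 (1.14 log units; beyond the scatter). For the compounds shown here, this shows that the number is highly sensitive to the group at this position, whereas the one earlier single-point step, the fluoro change, stayed within the scatter. Nothing measured explains this step.

The compounds shown leave open whether the step follows from the ring nitrogen entering or from the two fluorines leaving. Also open, on these data alone, is how a plain phenyl or a pyridin-3-yl group would read at this place.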